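Moving the Nitrile: 3-Cyanophenyl to 2-Cyanophenyl

The source may report more compounds than this note shows. Statements on the series, on what has been measured and on what is new or still open speak of the compounds shown alone.

Three compounds share one core and a 3-cyanophenyl group, and differ only in the saturated ring carried on the chain: compound 1 (`COc1cc2c(Nc3cccc(C#N)c3)ncnc2cc1OCCCN1CCCCC1`), compound 2 (`COc1cc2c(Nc3cccc(C#N)c3)ncnc2cc1OCCCN1CCC(C)CC1`) and compound 3 (`COc1cc2c(Nc3cccc(C#N)c3)ncnc2cc1OCCCN1CCN(C)CC1`). In a functional assay on DU-145 cells (Homo sapiens) for antiproliferative activity, read by MTT assay, with a stated time of 72 h (on this read-out higher numbers stand for weaker inhibition and lower numbers for stronger inhibition), compound 1 gives 29100 nM, compound 2 gives 17700 nM and compound 3 gives 12100 nM. The measured steps are a 1.6-fold lower number from compound 1 to compound 2 (0.22 log units; within the scatter), a 1.5-fold lower number from compound 2 to compound 3 (0.17 log units; within the scatter) and a 2.4-fold lower number from compound 1 to compound 3 (0.38 log units; beyond the scatter). Compound 3 therefore stands level with compound 2 at the low end of this small set, and is clearly separated from compound 1 alone.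

Compound 4 (`COc1cc2c(Nc3ccccc3C#N)ncnc2cc1OCCCN1CCN(C)CC1`) keeps the chain and the 4-methylpiperazin-1-yl group of compound 3, and the change lies elsewhere: 2-cyanophenyl in place of 3-cyanophenyl on a nitrogen on an aromatic ring. Within the data shown here, no measured step touches this group, so the data hold no direct evidence on moving the nitrile. The side-chain steps bear on it only as a guide to size, the largest being modest at a 2.4-fold lower number from compound 1 to compound 3 (0.38 log units; beyond the scatter). The step expected is a 1.2-fold higher number from compound 3 to compound 4 (0.06 log units; within the scatter), with no direction firmly supported, so nothing beyond the scatter is predicted. In this assay, compound 4 is estimated at 14000 nM, with an expected range of 5000 nM to 35000 nM.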

Compound 4, half-maximal inhibitory concentration: 19400 nM
For compound 4 the middle estimate is 1.4-fold (0.14 log units) below the measured one; low and high end bracket the measured number.
By their numbers in this assay, from the lowest: compounds 3, 2, 4 and 1 (each within the scatter of the next, the first and the last beyond it).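

In this assay, the first measured move of the nitrile gives a 1.6-fold higher number from compound 3 to compound 4 (0.21 log units; within the scatter), so at this position 2-cyanophenyl and 3-cyanophenyl on a nitrogen on an aromatic ring cannot be told apart on this read-out. The earlier compounds shown here all carried 3-cyanophenyl and varied only the saturated ring on the chain, so they said nothing about this group; this pair now shows that a change that keeps the same atoms and only joins them differently leaves compound 4 within the scatter of compound 3, although this rests on a single pair, both members of which carry 4-methylpiperazin-1-yl. The data offered here contain no measurement that would account for this outcome.

As far as these compounds go, it remains open whether the same move of the nitrile would also stay within the scatter with piperidin-1-yl or 4-methylpiperidin-1-yl on the chain, as 2-cyanophenyl appears here only with 4-methylpiperazin-1-yl. From the compounds shown here alone, it is equally open what a plain phenyl ring without the nitrile, or a chlorine or an ethynyl group in its place, would give in this assay.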